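The compounds below may be only part of what the source reports. "The series", "measured", "known", "first", "only" and "open" are said of these compounds alone.

Measured so far:
- compound 1 `CC(CCc1ccc(-c2ccccc2)cc1)CC(=O)O`: 20000 nM
- compound 2 `CC(CC(=O)O)CC(=O)c1ccc(Sc2ccccc2)cc1`: 570000 nM

Both were run in an assay (strain CD) for inhibition of 3-hydroxy-3-methylglutaryl-coenzyme A reductase (Rattus norvegicus), read by scintillation counting, using microsomes, with a stated time of 90 min; a lower number here means a stronger inhibitor, a higher number a weaker inhibitor. Of the two numbers, compound 1 gives the lower one at 20000 nM; compound 2 gives the higher one, at 570000 nM, and that gap lies beyond the usual scatter. Compound 2 is not a single-point relative of compound 1, so nothing about one change can be drawn from the pair; only the two values themselves are known.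

The next compound, compound 3 `CC(CCc1ccc(Oc2ccccc2)cc1)CC(=O)O`, has not yet been run in this assay. It follows from compound 1 by one change: phenoxy in place of phenyl on an aromatic carbon. Among the compounds with values here, no measured pair shows this change, so the size of the step has to be guessed from the single starting point. The expectation is a small step, if any, in the direction of a lower number, not clearly beyond the scatter.

Compound 3 is therefore estimated at 15000 nM in this assay, within a range of 5000 nM to 60000 nM. That estimate means a step of a 1.3-fold lower number from compound 1 to compound 3 (0.12 log units; within the scatter), which is expected to stay close to the scatter.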

Compound 3, half-maximal inhibitory concentration: 30000 nM
Compound 3: the middle estimate sits 2.0-fold (0.30 log units) below what was measured; measured number inside the range.
By their numbers in this assay, from the lowest: compounds 1 and 3 (each within the scatter of the next); then compound 2.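

In this assay, phenoxy in place of phenyl on an aromatic carbon, para to a group of 8 heavy atoms, gives a 1.5-fold higher number from compound 1 to compound 3 (0.18 log units; within the scatter). At this position, the two groups therefore cannot be told apart in this series, even though phenoxy adds an oxygen and a hydrogen-bond acceptor to the six-membered aromatic ring that both groups carry. No measured evidence bears on this result, so the reading stops at the size of the step.

As far as these compounds go, whether the same position would respond differently to a benzyloxy group, a methoxy group or an amine remains open, as does the effect of replacing the carboxylic acid of the shared core with an amide or a tetrazole. Compound 2 still has no single-change link to either compound 1 or compound 3, so the individual contributions of its ketone and its phenylthio group remain unresolved.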